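Ethyl in place of benzyl on the ring amine

The source may hold more compounds than are shown below. What is called first, only, known or untested is meant among the compounds shown, and "the series" means these compounds.

Compound 3 `Cc1nc(NCc2ccccc2)c2cnn(-c3ccccc3)c2n1` stands at the upper edge of what is shown: in a functional assay on G-361 cells (Homo sapiens) for cytotoxicity, read by sulforhodamine B assay (on this read-out lower numbers stand for stronger inhibition of growth and higher numbers for weaker inhibition of growth), compound 3 gives > 100000 nM, which is a limit of the assay and not a number. Compound 2 `Cc1nc(Nc2ccccc2)c2cnn(-c3ccccc3)c2n1` likewise gives > 100000 nM, again a limit. Among the compounds with values here, compound 1 `Cc1nc(NC(C)C)c2cnn(-c3ccccc3)c2n1` gives 32000 nM and so carries the only read number. The change to compound 4 `CCNc1nc(C)nc2c1cnn2-c1ccccc1` is methyl in place of phenyl on a saturated chain carbon bound to a nitrogen on an aromatic ring. Within the data shown here, the steps that bear on it are an at least 3.1-fold higher number from compound 1 to compound 3 (0.49 log units; beyond the scatter) and an at least 3.1-fold higher number from compound 1 to compound 2 (0.49 log units; beyond the scatter), both pointing the same way: the isopropyl of compound 1 stood for stronger growth inhibition than either aromatic or benzylic substituent. The step that the two limits leave unreadable from compound 2 to compound 3 adds nothing readable. Returning to a small alkyl is therefore expected to lower the number in this assay by a step of roughly the size seen before, with the limit on compound 3 leaving the true starting point open. For compound 4 the expected value in this assay is 40000 nM, with a range from 15000 nM to 150000 nM, because compound 1 gives 32000 nM. This estimate means an expected step of an at least 2.5-fold lower number from compound 3 to compound 4 (0.39 log units; beyond the scatter) in this assay.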

Compound 4, concentration for 50% growth inhibition: 38700 nM
Compound 4: middle estimate off by 1.0-fold (0.01 log units), on the high side; measured number inside the range.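

In this assay, ethyl in place of benzyl on the ring amine gives an at least 2.5-fold lower number from compound 3 to compound 4 (0.41 log units; beyond the scatter), and ethyl in place of phenyl gives an at least 2.5-fold lower number from compound 2 to compound 4 (0.41 log units; beyond the scatter), so a read number returns with a small alkyl group in both comparisons. Against the isopropyl of compound 1, the change gives a 1.2-fold higher number from compound 1 to compound 4 (0.08 log units; within the scatter), so ethyl and isopropyl cannot be told apart on this read-out. From the compounds shown here alone, the values of compound 2 and compound 3 are limits of the assay and not numbers, so the true size of both steps to compound 4 stays open: the limit of > 100000 nM in this assay, at which 2 of the 4 values shown sit.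

The compounds shown leave open whether a longer chain, such as butyl, would hold this level on the ring amine. They also leave open how a chain ending in an amine or a carboxylic acid would read here.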